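From Hydroxy to Pyridin-2-yl on an Amide Nitrogen

A few compounds are considered here, and "the series" means these few. Any claim that something is new, unique, unknown or untested is made for them only; others in the source may bear on it.

Within the data shown here, in a functional assay on HO8910 cells (Homo sapiens) for inhibition, read by MTT assay, with a stated time of 24 h, tested at 100 ug/mL (a higher number here means more inhibition of growth at the concentration tested, a lower number less inhibition of growth), compound 1 (`O=C(CCCCC(S)CCS)NO`) gives 49.3% as the higher of the two numbers so far. Compound 2 (`O=C(CCCCC(S)CCS)Nc1cccc(C(F)(F)F)c1`) gives 34.8% and that gap lies beyond the usual scatter of repeated measurements. Next comes compound 3 (`O=C(CCCCC(S)CCS)Nc1ccccn1`), which has not yet been measured. It keeps the core of compound 1 but carries pyridin-2-yl in place of hydroxy on an amide-type nitrogen. Among the measured compounds shown here, no measured pair shows what this exchange does on its own, so any forecast stays loose. For the measured compounds named here, the only guide is compound 2 at 34.8% and it points downward from compound 1 at 49.3% without settling the matter. In this assay a moderate fall is expected, estimated as a number 13.3 percentage points lower from compound 1 to compound 3 (beyond the scatter) for this exchange. For compound 3 the expected value is 36% with a likely range from 20% to 52% as an estimate only.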

Compound 3, percent growth inhibition at one concentration: 14.2%
Compound 3: middle estimate off by 21.8 percentage points, on the high side; the whole stated range lies above it.
By their numbers in this assay, from the lowest: compound 3; then compound 2; then compound 1.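

In this assay the exchange of hydroxy for pyridin-2-yl on the amide-type nitrogen brings a large loss of growth inhibition (a number 35.1 percentage points lower from compound 1 to compound 3 (beyond the scatter)). Among these compounds, this is the first step measured as a single change at this position, and it shows that this one group, with the rest of the core of compound 1 held fixed, can remove much of the inhibition. Nothing measured here explains the loss.

On these data alone, whether a plain phenyl ring, a methoxy group or an amino group in the same place would keep more of the inhibition remains open. So does the question of whether a pyridin-3-yl group, with its ring nitrogen elsewhere, would give a similar result.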